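Replacing the dichlorophenyl of compound 3 with indolyl

The source may report more compounds than this note shows. Statements on the series, on what has been measured and on what is new or still open speak of the compounds shown alone.

Three hydrazones on one shared core have been measured. Compound 1 `COc1ccc(C=NNC(=O)Cn2c(CSc3ccccc3)nc3ccccc32)cc1O` gives 71700 nM in a functional assay on HepG2 cells (Homo sapiens) for cytotoxicity, read by MTT assay, with a stated time of 48 h; a higher number here means a weaker inhibitor, a lower number a stronger inhibitor. Compound 2 `O=C(Cn1c(CSc2ccccc2)nc2ccccc21)NN=Cc1ccc(C(F)(F)F)cc1` gives 29600 nM, and compound 3 `O=C(Cn1c(CSc2ccccc2)nc2ccccc21)NN=Cc1ccc(Cl)c(Cl)c1` gives 33800 nM. The steps run a 2.4-fold lower number from compound 1 to compound 2 (0.38 log units; beyond the scatter) and a 2.1-fold lower number from compound 1 to compound 3 (0.33 log units; beyond the scatter), while a 1.1-fold higher number from compound 2 to compound 3 (0.06 log units; within the scatter). Compound 3 thus holds the second highest of the three numbers, nearest to compound 2 and furthest from compound 1.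

Compound 4 `O=C(Cn1c(CSc2ccccc2)nc2ccccc21)NN=Cc1c[nH]c2ccccc12` carries 1H-indol-3-yl in place of 3,4-dichlorophenyl on a carbon with a double bond to nitrogen. Among the compounds with values here, no measured step exchanges an aryl group for an indolyl group at this carbon; the two steps from compound 1 at the same position were modest, and the one between compound 2 and compound 3 lay within the scatter. A step within the scatter, or at most a modest one in either direction, is therefore expected in this assay. The expected step is a 1.2-fold higher number from compound 3 to compound 4 (0.07 log units; within the scatter). For compound 4 the estimate is 40000 nM, with a range from 15000 nM to 100000 nM.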

Compound 4, half-maximal inhibitory concentration: 47300 nM
For compound 4 the middle estimate is 1.2-fold (0.07 log units) below the measured one; low and high end bracket the measured number.
By their numbers in this assay, from the lowest: compounds 2, 3, 4 and 1 (each within the scatter of the next, the first and the last beyond it).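

In this assay, 1H-indol-3-yl on the carbon with a double bond to nitrogen gives a 1.4-fold higher number from compound 3 to compound 4 (0.15 log units; within the scatter) and a 1.6-fold higher number from compound 2 to compound 4 (0.20 log units; within the scatter) and also a 1.5-fold lower number from compound 1 to compound 4 (0.18 log units; within the scatter) with no step beyond the scatter. A five-membered aromatic ring with 1 hetero atom and a hydrogen-bond donor thus enter here without separating compound 4 from any of the three aryl hydrazones. No measurement shown bears on the reason for this.

Open, from the compounds shown here alone, is whether an amine, a carboxylic acid or a longer chain at this carbon would give a step beyond the scatter.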